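The source may hold more compounds than are shown below. What is called first, only, known or untested is meant among the compounds shown, and "the series" means these compounds.

In a functional assay on A549 cells (Homo sapiens) for cytotoxicity, read by MTT assay, with a stated time of 72 h (on this read-out lower numbers stand for stronger inhibition and higher numbers for weaker inhibition), compound 1 `O=C(/C=C/c1cccc(Cl)c1Cl)Nc1cc2c(Nc3ccc(F)c(Cl)c3)ncnc2cc1O[C@H]1CCOC1` gives 23200 nM, a weak result. Compound 2 `N#Cc1ccc(/C=C/C(=O)Nc2cc3c(Nc4ccc(F)c(Cl)c4)ncnc3cc2O[C@H]2CCOC2)cc1` is reported as "not active" (no number reported), so it stands without a number and at the weak end of this small set. Compound 3 `COc1ccc(OC)c(/C=C/C(=O)Nc2cc3c(Nc4ccc(F)c(Cl)c4)ncnc3cc2O[C@H]2CCOC2)c1` carries 2,5-dimethoxyphenyl in place of 4-cyanophenyl on a double-bonded chain carbon bound to a double-bonded chain carbon. Going by the values given here, no measured step covers this change, so only a modest move towards stronger inhibition is expected, into the measurable weak range where compound 1 sits at 23200 nM. For compound 3 the expected value is about 25000 nM, with an estimated range of 10000 nM to 60000 nM.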

Compound 3, half-maximal inhibitory concentration: 7300 nM
Beside the measured number, compound 3's estimate is 3.4-fold (0.53 log units) above it; the measured number lies below the stated range.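

In this assay, the ring group on a double-bonded chain carbon bound to a double-bonded chain carbon does affect the read-out: 2,5-dimethoxyphenyl in place of 2,3-dichlorophenyl gives a 3.2-fold lower number from compound 1 to compound 3 (0.50 log units; beyond the scatter) and the number stays in the weak range. Compound 2, with 4-cyanophenyl, has no number, so its step to compound 3 cannot be read. Nothing available explains the difference. Going by these compounds, it remains open whether a phenyl ring carrying a single methoxy group would match compound 3, and how one carrying an amine or a carboxylic acid would compare.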